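Cytotoxicity notes: from compound 2 to compound 3

This account rests on a few compounds, and the source may have more. Where it says the series, first, only, none or still open, it means among the compounds named here.

Compound 1, `CC(=O)c1cc(C(=O)N[C@@H](C)Cn2ccc(-c3cc(F)c(C#N)c(Cl)c3)n2)n[nH]1`, is one of the two compounds measured in an ADME assay on PC-3 cells (Homo sapiens) for cytotoxicity, read by CCK-8 assay, with a stated time of 6 days; on this read-out lower numbers stand for stronger inhibition and higher numbers for weaker inhibition. In this assay compound 1 returns only a limit of the assay, > 30000 nM. Compound 2, `CC(O)c1cccc(C(=O)N[C@@H](C)Cn2ccc(-c3ccc(C#N)c(Cl)c3)n2)c1`, is the other. In this assay compound 2 likewise returns only a limit of the assay, > 30000 nM. Compound 2 therefore stands exactly where every value shown stands: the limit of > 30000 nM in this assay, at which 2 of the 2 values shown sit. Among the compounds with values here, no step between measured compounds is known.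

Compound 3, `COC(=O)/C=C/C(=O)N[C@@H](C)Cn1ccc(-c2ccc(C#N)c(Cl)c2)n1`, has not yet been measured in this assay. It differs from compound 2 in one place: 2-(methoxycarbonyl)ethenyl in place of 3-(1-hydroxyethyl)phenyl on a carbonyl carbon.

Because both values shown sit at the limit of > 30000 nM in this assay, at which 2 of the 2 values shown sit, nothing in the data shows how far a change at this carbonyl carbon moves the read-out in either direction. The expectation is that compound 3 stays at or near the same limit, with a step from compound 2 expected to be none beyond the scatter, a number no higher from compound 2 to compound 3 (the limit leaves the size open). The estimate for compound 3 in this assay is 30000 nM, within 10000 nM to 90000 nM, and most likely reported again as a limit rather than a number.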

Compound 3, half-maximal inhibitory concentration: > 30000 nM
Compound 3 was reported as a limit (the forecaster's own chance of this, stated with the estimate: 75%); the middle value lies on the limit itself.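

No step can be read from compound 2 to compound 3 in this assay, as each compound gives only a limit of the assay: the limit of > 30000 nM in this assay, at which 3 of the 3 values shown sit.

The compounds shown leave open how far any change on this carbonyl carbon moves the read-out, and whether any member of the series gives a number rather than a limit.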